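The source may hold more compounds than are shown below. What is called first, only, known or untested is meant among the compounds shown, and "the series" means these compounds.

Going by the values given here, compound 2 `CCC(C)NC(=O)c1nc(-c2cccs2)[nH]c(=O)c1O` gives 1300 nM in an assay on isolated protein for inhibition of Flap endonuclease 1 (Homo sapiens) (on this read-out higher numbers stand for weaker inhibition and lower numbers for stronger inhibition), and stands lowest of the two numbers so far; the nearest is compound 1 `O=C(NCCO)c1nc(-c2cccs2)[nH]c(=O)c1O`, which gives 4000 nM in this assay. Among the compounds with values here, the only measured step, a 3.1-fold lower number from compound 1 to compound 2 (0.49 log units; beyond the scatter), came from sec-butyl in place of 2-hydroxyethyl on an amide-type nitrogen. Compound 3 `CC(C)CCNC(=O)c1nc(-c2cccs2)[nH]c(=O)c1O` differs from compound 2 by isopentyl in place of sec-butyl on an amide-type nitrogen. Within the data shown here, that earlier step is the only one bearing on this change, and it was modest; it exchanged a hydroxy-bearing chain for an alkyl, whereas the present change keeps an alkyl on both sides, so it is a weak guide. The expected step from compound 2 to compound 3 is therefore small, within the scatter, as a 1.2-fold lower number from compound 2 to compound 3 (0.07 log units; within the scatter). The estimate for compound 3 in this assay is 1100 nM. For compound 3 the range is expected to run from 400 nM to 3000 nM.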

Compound 3, half-maximal inhibitory concentration: 3500 nM
Beside the measured number, compound 3's estimate is 3.2-fold (0.50 log units) below it, and the stated range ends below it.
By their numbers in this assay, from the lowest: compound 2; then compounds 3 and 1 (each within the scatter of the next).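

At this amide-type nitrogen in this assay, the choice of alkyl group matters: a 2.7-fold higher number from compound 2 to compound 3 (0.43 log units; beyond the scatter), so exchanging sec-butyl for isopentyl is not a neutral change. Isopropyl in place of hydroxy on the saturated chain gives a 1.1-fold lower number from compound 1 to compound 3 (0.06 log units; within the scatter), so the isopentyl and 2-hydroxyethyl amides stand level, and the lower number of compound 2 cannot be read as a general gain from replacing a hydroxy-bearing chain with an alkyl. Nothing available accounts for the difference between the two alkyl groups.

Sec-butyl and isopentyl differ in both carbon count and branching, so the contribution of each remains unresolved. An n-butyl or tert-butyl group on the same nitrogen would help separate the two, while a chain ending in an amine or a carboxylic acid remains an open comparison with the hydroxy-bearing chain.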